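Removing the aromatic bromine from compound 2: cytotoxicity notes

The source may hold more compounds than are shown below. What is called first, only, known or untested is meant among the compounds shown, and "the series" means these compounds.

The series shares one core, seen in compound 1 `C=C1C[C@]23C[C@@]1(O)CC[C@H]2c1cc2c(C(=O)O)coc2c(C)c1[C@@H]3C(=O)O` and compound 2 `C=C1C[C@]23C[C@@]1(O)CC[C@H]2c1cc(Br)c(O/C=C/C(=O)OC)c(C)c1[C@@H]3C(=O)OC`, and is followed in a functional assay on SUD4 cells (Homo sapiens) for cytotoxicity, read by luminescence and CellTiter-Glo, with a stated time of 24 h; on this read-out higher numbers stand for weaker inhibition and lower numbers for stronger inhibition. In this assay compound 1 gives > 10000 nM, a limit of the assay rather than a number. In this assay compound 2 likewise gives > 10000 nM, again only a limit. Among the measured compounds shown here, compound 2 therefore sits at the limit, with no numeric value of its own; the one further value shown, for compound 1, is a limit as well, so no ordering between the two can be drawn. For the measured compounds named here, the single piece of evidence on the measured material is the limit of > 10000 nM in this assay, at which 2 of the 2 values shown sit.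

Compound 3 `C=C1C[C@]23C[C@@]1(O)CC[C@H]2c1ccc(O/C=C/C(=O)OC)c(C)c1[C@@H]3C(=O)OC` is the next compound to be measured in this assay. Its change from compound 2 is hydrogen in place of bromo on an aromatic carbon. Going by the values given here, no step between two measured compounds is available, so the effect of this change is untested here. The expected step that the limit leaves unreadable from compound 2 to compound 3 is none beyond the scatter, since both measured compounds sit only at the limit of > 10000 nM in this assay, at which 2 of the 2 values shown sit. For compound 3 the estimate in this assay is 15000 nM, with a range from 5000 nM to 50000 nM, most likely reported again as a limit.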

Compound 3, half-maximal inhibitory concentration: > 10000 nM
Compound 3 gave a limit, no number (the forecaster's own chance of this, stated with the estimate: 85%); the middle value lies beyond the limit too.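

No new step can be read between compound 2 and compound 3 in this assay, since the replacement of bromo by hydrogen links two results that are both limits and not numbers: the limit of > 10000 nM in this assay, at which 3 of the 3 values shown sit.

The compounds shown leave open whether the bromo group affects cytotoxicity at all, and whether any compound on the shared core gives a numeric value in this assay.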